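The compounds below may be only part of what the source reports. "The series", "measured", "known", "first", "only" and "open" are said of these compounds alone.

Measured so far:
compound 1, `COc1ccc(/C=C2\CCC/C(=C\c3cccc(OC)c3OC)C2=O)cc1`, 13600 nM
compound 2, `COc1ccc(/C=C2\CCC/C(=C\c3ccccc3Cl)C2=O)cc1OC`, 7100 nM

Both numbers come from a functional assay on SW-620 cells (Homo sapiens) for cytotoxicity, read by MTT assay, with a stated time of 72 h; a lower number here means a stronger inhibitor, a higher number a weaker inhibitor. Compound 1 gives 13600 nM and compound 2 gives 7100 nM in this assay; the two values lie within the usual scatter of each other, so neither compound can be said to stand apart from the other on what has been measured.

The unmeasured compound 3, `COc1ccc(/C=C2\CCC/C(=C\c3cc(Cl)cc(Cl)c3)C2=O)cc1OC`, shares the core of compound 2 and differs from it in one place: 3,5-dichlorophenyl in place of 2-chlorophenyl on a double-bonded chain carbon bound to a double-bonded ring carbon.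

Going by the values given here, no step between two measured compounds is available to show what such a change does here. With nothing to lean on, the expectation is that the step of a 1.4-fold lower number from compound 2 to compound 3 (0.15 log units; within the scatter) will stay small, perhaps a modest drop, but not clearly beyond the scatter in either direction. Compound 3 is therefore estimated at 5000 nM in this assay, with a range from 1500 nM to 16000 nM.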

Compound 3, half-maximal inhibitory concentration: 2500 nM
Compound 3: the middle estimate sits 2.0-fold (0.30 log units) above what was measured, and the stated range covers the measured number.
By their numbers in this assay, from the lowest: compound 3; then compounds 2 and 1 (each within the scatter of the next).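

In this assay, going by these compounds alone, 3,5-dichlorophenyl in place of 2-chlorophenyl on a double-bonded chain carbon bound to a double-bonded ring carbon gives the only step so far that clears the scatter (a 2.8-fold lower number from compound 2 to compound 3 (0.45 log units; beyond the scatter)). This shows that the number responds to what is carried at this place, though the step is modest and rests on a single pair of compounds. The swap changes both how many chlorines the ring carries and where they sit, and no other measurement is at hand to explain the drop.

The compounds shown leave open whether the number of chlorines or their placement matters more. They also do not tell how this place would respond to a phenyl ring carrying an amine or a carboxylic acid.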